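The source may report more compounds than this note shows. Statements on the series, on what has been measured and on what is new or still open speak of the compounds shown alone.

The measured compounds:
compound 1, `CN(C)c1ccc2c(=O)c(C(=O)Nc3cc(F)cc(F)c3)cn(-c3ccc(OCCCCCCC[n+]4ccccc4)c(Cl)c3)c2n1`, gives 21.4% in an assay on LX2 cells for inhibition of COL1A1 promoter (Homo sapiens), read by a luciferase reporter, with a stated time of 24 h, tested at 50 uM; a higher number here means a stronger effect of the compound at the concentration tested, a lower number a weaker effect;
compound 2, `Cc1cc(OCCCCCCC[n+]2ccccc2)cc(-n2cc(C(=O)Nc3cc(F)cc(F)c3)c(=O)c3ccc(N(C)C)nc32)c1`, gives 61%;
compound 3, `CC[N+]1(CCCCCCCOc2ccc(-n3cc(C(=O)Nc4cc(F)cc(F)c4)c(=O)c4ccc(N(C)C)nc43)cc2Cl)CCCCC1`, gives 50.4%.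

Compound 1 and compound 3 differ in one place: a group of 8 heavy atoms (7 carbon, 1 nitrogen; one six-membered non-aromatic ring with 1 hetero atom) in place of a group of 6 heavy atoms (5 carbon, 1 nitrogen; one six-membered aromatic ring with 1 hetero atom), on a saturated chain carbon, seven bonds along the chain from an oxygen on an aromatic ring. This change made the step of a number 29 percentage points higher from compound 1 to compound 3 (beyond the scatter). Compound 2 has a different core; the difference between the two cores is not broken down here. Its gap to compound 3 lies beyond the scatter, and compound 2 stands highest of the three measured.

The compound not yet measured is compound 4, `CC[N+]1(CCCCCCCOc2cc(C)cc(-n3cc(C(=O)Nc4cc(F)cc(F)c4)c(=O)c4ccc(N(C)C)nc43)c2)CCCCC1`. It stands to compound 2 as compound 3 stands to compound 1: a group of 8 heavy atoms (7 carbon, 1 nitrogen; one six-membered non-aromatic ring with 1 hetero atom) in place of a group of 6 heavy atoms (5 carbon, 1 nitrogen; one six-membered aromatic ring with 1 hetero atom), on a saturated chain carbon, seven bonds along the chain from an oxygen on an aromatic ring. The place is the same word for word, so this is the same change. A rise is expected here too, because the step of a number 29 percentage points higher from compound 1 to compound 3 (beyond the scatter) was in the raising direction, but a smaller one, because compound 2 already gives 61% and the read-out cannot pass full inhibition. The expected step is a number 11 percentage points higher from compound 2 to compound 4 (beyond the scatter). Compound 4 is estimated at 72%, in a likely range from 52% to 90%.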

Compound 4, a percentage reported as inhibition, at one concentration (the size of the read-out at that concentration, not a potency): 86.6%
For compound 4 the middle estimate is 14.6 percentage points below the measured one; the range from low to high includes it.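

Replacing the six-membered aromatic ring at the end of the chain with the six-membered non-aromatic ring gives, in this assay, a number 25.6 percentage points higher from compound 2 to compound 4 (beyond the scatter). The change therefore carries from the core of compound 1 to the core of compound 2 with a step of much the same size: the same change on two cores in this assay, a number 29 percentage points higher (beyond the scatter) from compound 1 to compound 3 and a number 25.6 percentage points higher (beyond the scatter) from compound 2 to compound 4, 3.4 percentage points apart, within the scatter of two such steps. Going by these compounds alone, this rests on only two pairs, two cores and a single tested concentration, so it does not show that the rise would hold on any other core, and it does not explain why the change raises the read-out or give a potency for either compound.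

The compounds shown leave open how a morpholine ring or an open-chain amine at the end of the chain would compare, and whether a shorter or longer chain would keep the step. They also leave open whether the same step would appear at lower concentrations.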